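From one 2-cyanoethyl chain to two

This account rests on a few compounds, and the source may have more. Where it says the series, first, only, none or still open, it means among the compounds named here.

Measured in a functional assay on Caco-2 cells (Homo sapiens), read by MTT assay, with a stated time of 48 h; a lower number here means a stronger inhibitor, a higher number a weaker inhibitor:
Compound 1 `CCN(CC)CCNC(=O)c1ccc(C(CC)(CC)c2ccc(OCC(O)C(C)(C)C)c(C)c2)n1CC`: 2310 nM
Compound 2 `CCn1c(C(=O)NCC(OC)OC)ccc1C(CC)(CC)c1ccc(OCC(O)C(C)(C)C)c(C)c1`: > 50000 nM (a limit)
Compound 3 `CCn1c(C(=O)N(C)CCC#N)ccc1C(CC)(CC)c1ccc(OCC(O)C(C)(C)C)c(C)c1`: > 50000 nM (a limit)

Compound 3 reads > 50000 nM, which is a limit and not a number. It therefore stands at the limit of > 50000 nM in this assay, at which 2 of the 3 values shown sit.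

Compound 4 `CCn1c(C(=O)N(CCC#N)CCC#N)ccc1C(CC)(CC)c1ccc(OCC(O)C(C)(C)C)c(C)c1` keeps the core of compound 3 and differs in one place: cyanomethyl in place of hydrogen on a saturated chain carbon bound to an amide-type nitrogen. Cyanomethyl takes the place of hydrogen on a saturated chain carbon bound to an amide-type nitrogen, so methyl becomes 2-cyanoethyl.

For the measured compounds named here, no measured step makes this exact change. The nearest evidence is an at least 21-fold higher number from compound 1 to compound 3 (1.33 log units; beyond the scatter), a large step, and an at least 21-fold higher number from compound 1 to compound 2 (1.33 log units; beyond the scatter), equally large. Both leave the diethylamino group of compound 1 behind, and compound 4 does not regain it. Also relevant is a step that the two limits leave unreadable from compound 2 to compound 3.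

A recovery of activity therefore seems unlikely, and no step beyond the scatter is expected in this assay. The expected step is a number no higher from compound 3 to compound 4 (the limit leaves the size open). The estimated value for compound 4 is 50000 nM, with an expected range of 20000 nM to 100000 nM.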

Compound 4, half-maximal inhibitory concentration: 7100 nM
Estimate against measurement, compound 4: 7.0-fold (0.85 log units) above; measured number below the stated range.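

Cyanomethyl in place of hydrogen on a saturated chain carbon bound to an amide-type nitrogen brings an at least 7.0-fold lower number from compound 3 to compound 4 (0.84 log units; beyond the scatter) in this assay, so activity can return without the diethylamino group of compound 1. The same compound also stands clear of the dimethoxy side chain, with an at least 7.0-fold lower number from compound 2 to compound 4 (0.84 log units; beyond the scatter), yet it does not fully match compound 1, with a 3.1-fold higher number from compound 1 to compound 4 (0.49 log units; beyond the scatter). Compound 3 carries a limit and not a number, so the true size of the gain stays open: the limit of > 50000 nM in this assay, at which 2 of the 4 values shown sit.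

A propyl chain in place of 2-cyanoethyl is the comparison that would separate the nitrile from the added chain length. From the compounds shown here alone, whether a longer chain ending in a nitrile, or a chain ending in a carboxylic acid, would keep or lose this gain also remains open.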